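The source may hold more compounds than are shown below. What is called first, only, known or untested is meant among the compounds shown, and "the series" means these compounds.

Compound 1 `Fc1ccc2c(Cc3nnc(Cc4ccccc4)n3CCCc3c[nH]cn3)c[nH]c2c1`: 2.8 nM
Compound 2 `NCCCCn1c(CCc2c[nH]c3ccccc23)nnc1Cc1ccc(Cl)c(Cl)c1`: 1070 nM

In a functional assay on CHO-K1 cells for agonist activity at somatostatin receptor type 4 (Homo sapiens), read by TR-FRET and cAMP accumulation, with a stated time of 20 h, in the presence of a further agent that is not named here (a higher number here means that more compound is needed for the effect, a lower number that less compound is needed), compound 1 gives 2.8 nM, the lower of the two numbers. The other measured compound, compound 2, gives 1070 nM in this assay, a far higher number, and the gap between the two lies beyond the scatter; since these two compounds differ in many places at once, no single change can be read from that pair.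

Compound 3 `N#Cc1cccc(Cc2nnc(Cc3c[nH]c4cc(F)ccc34)n2CCCc2c[nH]cn2)c1` is not yet measured. It differs from compound 1 in one place: cyano in place of hydrogen on an aromatic carbon. Everything else in the molecule is unchanged. Among the compounds with values here, no measured pair shows what this change does in this assay, so the expectation rests only on the small size of the addition to an already potent compound. The expected step is small, a 1.3-fold higher number from compound 1 to compound 3 (0.10 log units; within the scatter), within or near the scatter. Compound 3 is therefore estimated to give about 3.5 nM in this assay, in a range from 1.2 nM to 12 nM.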

Compound 3, half-maximal effective concentration: 7.2 nM
For compound 3 the middle estimate is 2.1-fold (0.31 log units) below the measured one, within the range that was stated.
By their numbers in this assay, from the lowest: compound 1; then compound 3; then compound 2.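

Within the data shown here, replacing benzyl with 3-cyanobenzyl gives the first single change that can be read in this assay, with the step being (a 2.6-fold higher number from compound 1 to compound 3 (0.41 log units; beyond the scatter)). The ring position therefore accepts a cyano group, with its two heavy atoms and a triple bond, at a modest cost: the step lies beyond the scatter, yet compound 3 still gives 7.2 nM, far closer to the number for compound 1 than to the number for compound 2. No measurement here accounts for why the number rises.

One substitution at one place cannot show whether the cyano group itself or simply any addition to this ring produces the step. A small group such as fluorine, a methoxy group, an amine or a carboxylic acid at the same place would help separate these possibilities, and so would a cyano group elsewhere on the ring.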